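The compounds below may be only part of what the source reports. "The series", "measured", "known", "first", "only" and "open" are said of these compounds alone.

Measured in a functional assay on SK-OV-3 cells (Homo sapiens) for antiproliferative activity, read by MTT assay, with a stated time of 24 h; a higher number here means a weaker inhibitor, a lower number a stronger inhibitor:
- compound 1 `COc1cccc(/C=C/C(=O)c2ccc(OC)c3c2OC(C)(C)C=C3)c1`: 9360 nM
- compound 2 `COc1ccc(C(=O)/C=C/c2ccc([N+](=O)[O-])cc2)c2c1C=CC(C)(C)O2`: 3420 nM
- compound 3 `COc1ccc(/C=C/C(=O)c2ccc(OC)c3c2OC(C)(C)C=C3)cn1`: > 10000 nM, a limit and not a number

Compound 3 has no number of its own, only the limit > 10000 nM. The step to compound 4 `COc1ccc(C(=O)/C=C/c2cccc(Cl)c2)c2c1C=CC(C)(C)O2` is a single exchange: 3-chlorophenyl in place of 6-methoxypyridin-3-yl on a double-bonded chain carbon bound to a double-bonded chain carbon.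

Three measured steps at this same place bear on it. Exchanging 3-methoxyphenyl for 4-nitrophenyl gave a 2.7-fold lower number from compound 1 to compound 2 (0.44 log units; beyond the scatter). Exchanging 4-nitrophenyl for 6-methoxypyridin-3-yl gave an at least 2.9-fold higher number from compound 2 to compound 3 (0.46 log units; beyond the scatter). The exchange of 3-methoxyphenyl for 6-methoxypyridin-3-yl gave an at least 1.0-fold higher number from compound 1 to compound 3 (0.02 log units; that floor lies within the scatter), so those two groups cannot be separated here.

None of these steps tests 3-chlorophenyl itself. The expectation therefore rests on the two compounds whose entering-type ring is of carbon only, with compound 1 at 9360 nM and compound 2 at 3420 nM. Compound 4 is expected to fall in that region, and a modest step toward a lower number is the likely direction, though a reading at the limit remains possible. The expected step is an at least 1.6-fold lower number from compound 3 to compound 4 (0.22 log units; that floor lies within the scatter). For compound 4 the estimated half-maximal inhibitory concentration is 6000 nM, with an expected range of 2500 nM to 12000 nM.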

Compound 4, half-maximal inhibitory concentration: > 10000 nM
Compound 4: a limit, no number; the forecaster's own chance of this, stated with the estimate: 20%; at least 1.6-fold (0.22 log units) between middle value and limit.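

In this assay compound 4 gives > 10000 nM, which is a limit and not a number. A ring of carbon only at this place is therefore not enough to bring the number down: exchanging 4-nitrophenyl for 3-chlorophenyl gave an at least 2.9-fold higher number from compound 2 to compound 4 (0.46 log units; beyond the scatter), so the lower number of compound 2 does not carry over to this other ring of carbon only. Chloro in place of methoxy on an aromatic carbon gave an at least 1.0-fold higher number from compound 1 to compound 4 (0.02 log units; that floor lies within the scatter), so those two groups cannot be separated here, the step between the two limits cannot be read, and the series now rests heavily on a single ceiling: the limit of > 10000 nM in this assay, at which 2 of the 4 values shown sit.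

Going by these compounds, since only compound 2 stands clear of that ceiling, it remains open whether its lower number belongs to the nitro group itself or to the place that group holds on the ring, which a 3-nitrophenyl or a 4-chlorophenyl ring on the same chain carbon would address. Also open, on these data alone, is how a 4-aminophenyl or a 4-carboxyphenyl ring would read at this place on the core of compound 2.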